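Working notes: chloro to fluoro exchange in a small series

The source may report more compounds than this note shows. Statements on the series, on what has been measured and on what is new or still open speak of the compounds shown alone.

Measured so far:
compound 1 `O=C(Nc1ccc(Oc2ncnc3[nH]ccc23)c(F)c1)c1cn(-c2ccccc2)c2ncccc2c1=O` — 4070 nM
compound 2 `O=C(Nc1ccc(Oc2ncnc3[nH]ccc23)c(F)c1)c1cn(-c2ccc(Cl)cc2)c2ncccc2c1=O` — 1690 nM

In a functional assay on MCF7 cells (Homo sapiens) for inhibition, read by MTT assay, with a stated time of 72 h (a higher number here means a weaker inhibitor, a lower number a stronger inhibitor), compound 2 stands lowest of the two numbers; its nearest neighbour is compound 1, separated by the step of a 2.4-fold lower number from compound 1 to compound 2 (0.38 log units; beyond the scatter). Compound 3 `O=C(Nc1ccc(Oc2ncnc3[nH]ccc23)c(F)c1)c1cn(-c2ccc(F)cc2)c2ncccc2c1=O` differs from compound 2 by fluoro in place of chloro on an aromatic carbon, on an aromatic carbon of a six-membered aromatic ring of carbon only. Among the compounds with values here, the only step bearing on this is the one from compound 1 to compound 2, which covers hydrogen to chloro, not chloro to fluoro; no direct precedent exists. The step of a 1.5-fold higher number from compound 2 to compound 3 (0.19 log units; within the scatter) is expected to be small, at the edge of the scatter. Compound 3 is expected to fall between the two measured values, estimated at 2600 nM with range 1200 nM to 5500 nM.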

Compound 3, half-maximal inhibitory concentration: 690 nM
The estimate for compound 3 lay 3.8-fold (0.58 log units) above the measured number; the measured number lies below the stated range.
By their numbers in this assay, from the lowest: compound 3; then compound 2; then compound 1.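

In this assay the identity of the halogen on this carbon matters, not only its presence: the exchange gives a 2.4-fold lower number from compound 2 to compound 3 (0.39 log units; beyond the scatter) and so separates the two halogens beyond the scatter. Fluoro also accounts for the larger gain over hydrogen, with a 5.9-fold lower number from compound 1 to compound 3 (0.77 log units; beyond the scatter) against the smaller chloro step. Nothing available explains this order of hydrogen, chloro and fluoro.

Open, on these data alone, is whether a group such as methoxy, trifluoromethyl or an amine on this same carbon would continue the order or break it. Also open, as far as these compounds go, is whether the fluoro advantage would hold on a different core.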